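The source may hold more compounds than are shown below. What is called first, only, known or untested is meant among the compounds shown, and "the series" means these compounds.

Series notes. Compound 2 `COc1cc(OC)c(OC)cc1/C=C/COC(=O)/C=C/c1ccc(F)cc1` gives 100% in a functional assay on the whole organism (strain Kunming) with Mus musculus as the target, with a stated time of 0.5 h, at a dose of 300 mg/kg by the intraperitoneal route; on this read-out higher numbers stand for a weaker effect at the one dose given and lower numbers for a stronger effect. Compound 1 `COc1ccccc1/C=C/C(=O)OC/C=C/c1cc(OC)c(OC)cc1OC` gives 100% in this assay, and the step of no change at the digits printed from compound 1 to compound 2 (within the scatter) was no change within the scatter, so compound 2 stands level with compound 1 at the digits shown; it has no nearer neighbour. Compound 3 `COc1cccc(/C=C/C(=O)OC/C=C/c2cc(OC)c(OC)cc2OC)c1` is not yet measured. It differs from compound 2 as follows: 3-methoxyphenyl in place of 4-fluorophenyl on a double-bonded chain carbon bound to a double-bonded chain carbon. Among the compounds with values here, the only measured step that bears on this change is the earlier swap of the aryl group on a double-bonded chain carbon bound to a double-bonded chain carbon, no change at the digits printed from compound 1 to compound 2 (within the scatter), which left the read-out unchanged within the scatter, with compound 1 and compound 2 sitting at the same level. On that basis the step expected in this assay is no change at the digits printed from compound 2 to compound 3 (within the scatter), none beyond the scatter in either direction. Compound 3 is therefore estimated at 100%, with a range from 85% to 100%.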

Compound 3, a percentage reported as activity, at one dose (the size of the read-out at that dose, not a potency): 100%
Beside the measured number, compound 3's estimate shows no gap at the digits printed; the range from low to high includes it.
By their numbers in this assay, from the lowest: compounds 1, 2 and 3 (each within the scatter of the next).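

At the place on a double-bonded chain carbon bound to a double-bonded chain carbon, this assay now gives two further readings of the aryl swap: no change at the digits printed from compound 2 to compound 3 (within the scatter) with 3-methoxyphenyl in place of 4-fluorophenyl, and no change at the digits printed from compound 1 to compound 3 (within the scatter) with 3-methoxyphenyl in place of 2-methoxyphenyl. The second step is new in kind, since it compares two methoxyphenyl groups and so separates where the methoxy group stands on the ring from the choice of substituent, and neither makes a difference beyond the scatter in these three compounds. No evidence on why the read-out stays level is available.

Still open, as far as these compounds go, is whether an aminophenyl or a carboxylic acid at this place would move the read-out away from this level. Also open, from the compounds shown here alone, is whether any change to the rest of the shared core would do so.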